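Urea to benzamide on the shared core

The source may hold more compounds than are shown below. What is called first, only, known or untested is meant among the compounds shown, and "the series" means these compounds.

Measured compounds:
- compound 1, `O=C(Nc1cccc(-n2cc(-c3ccncc3)c(-c3ccc(Cl)c(O)c3)n2)c1)Nc1cccc(C(F)(F)F)c1`; in a functional assay on NCI-H322M cells (Homo sapiens) for inhibition, read by sulforhodamine B assay, with a stated time of 48 h (on this read-out higher numbers stand for weaker inhibition of growth and lower numbers for stronger inhibition of growth), compound 1 reports only a limit, > 32500 nM.
- compound 2, `COc1cc(-c2nn(-c3cccc(NC(=O)Nc4cccc(C(F)(F)F)c4)c3)cc2-c2ccncc2)ccc1Cl`; in this assay compound 2 gives 4730 nM.

Among the compounds with values here, compound 2 holds the only number here; the value of compound 1 is a limit (the limit of > 32500 nM in this assay, at which 1 of the 2 values shown sits). Within the data shown here, the single measured step, an at least 6.8-fold lower number from compound 1 to compound 2 (0.83 log units; beyond the scatter), concerns the oxygen on the aromatic ring and not the carbonyl carbon. Compound 3, `COc1cc(-c2nn(-c3cccc(NC(=O)c4ccccc4)c3)cc2-c2ccncc2)ccc1Cl`, differs from compound 2 by phenyl in place of (3-(trifluoromethyl)phenyl)amino on a carbonyl carbon. Among the measured compounds shown here, no measured step touches this part of the molecule, so the expectation rests on the structural change alone. For compound 3 the estimate in this assay is 15000 nM, between 4000 nM and 40000 nM. This corresponds to an expected step of a 3.2-fold higher number from compound 2 to compound 3 (0.50 log units; beyond the scatter).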

Compound 3, concentration for total growth inhibition: > 100000 nM
Compound 3: a limit, no number; the forecaster's own chance of this, stated with the estimate: 30%; middle value at least 6.6-fold (0.82 log units) from the limit.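

Within the data shown here, this is the first measured change on the carbonyl carbon: in this assay, phenyl in place of (3-(trifluoromethyl)phenyl)amino gives an at least 21-fold higher number from compound 2 to compound 3 (1.32 log units; beyond the scatter). Growth inhibition on the shared core therefore depends on this place as well as on the oxygen substituent. Compound 3 reports only a limit: the limit of > 100000 nM in this assay, at which 1 of the 3 values shown sits.

Open, from the compounds shown here alone, is whether the amino nitrogen or the trifluoromethyl group matters more, as the two leave together in this step. A plain phenylamino group on the carbonyl carbon would separate them.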